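Cyclohexyl versus smaller groups on the pyrazole nitrogen

The compounds below may be only part of what the source reports. "The series", "measured", "known", "first", "only" and "open" are said of these compounds alone.

Measured so far in an assay on HEK293 cells for activation of Kir3.1/Kir3.2 (Homo sapiens), read by thallium flux; on this read-out lower numbers stand for an effect already at smaller amounts and higher numbers for an effect only at larger amounts of compound:
compound 1, `Cc1cc(NC(=O)Cn2nnc(-c3ccccc3)n2)n(C2CCCCC2)n1`: 96 nM
compound 2, `CCC(C)n1nc(C)cc1NC(=O)Cn1nnc(-c2ccccc2)n1`: > 5000 nM
compound 3, `Cc1cc(NC(=O)Cn2nnc(-c3ccccc3)n2)n(C2CC2)n1`: > 5000 nM

Compound 3 gives only a limit in this assay, > 5000 nM, and no number. The same holds for compound 2, whose value > 5000 nM is a limit too; two of the three values shown sit at the limit of > 5000 nM in this assay, at which 2 of the 3 values shown sit. Among the measured compounds shown here, the only numeric value belongs to compound 1, 96 nM, which carries the cyclohexyl group.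

Compound 4, `Cc1cc(NC(=O)Cn2nnc(-c3ccccc3)n2)n(C2CCS(=O)(=O)CC2)n1`, is the next member. The change from compound 3 is 1,1-dioxothian-4-yl in place of cyclopropyl on an aromatic nitrogen. For the measured compounds named here, two measured steps bear on it: an at least 52-fold higher number from compound 1 to compound 2 (1.71 log units; beyond the scatter) and an at least 52-fold higher number from compound 1 to compound 3 (1.71 log units; beyond the scatter), both large, both in the direction of weaker effect when cyclohexyl gives way to sec-butyl or cyclopropyl. The step that the two limits leave unreadable from compound 2 to compound 3 cannot be read, since both ends are limits. The group entering in compound 4 brings back a six-membered non-aromatic ring, as cyclohexyl has, though with a hetero atom and two oxygens that compound 1 lacks. It is therefore expected that compound 4 moves back toward a measurable value, with a step of an at least 8.3-fold lower number from compound 3 to compound 4 (0.92 log units; beyond the scatter) in the direction of a lower number, but the estimate stays wide: compound 4 is expected at 600 nM, between 80 nM and 5000 nM.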

Compound 4, half-maximal effective concentration: > 10000 nM
Compound 4: only a limit was reported (the forecaster's own chance of this, stated with the estimate: 35%); middle value at least 16-fold (1.22 log units) away from the limit.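

In this assay compound 4 gives only a limit, > 10000 nM, so the position still has a single numeric value: the limit of > 10000 nM in this assay, at which 1 of the 4 values shown sits A six-membered non-aromatic ring on the aromatic nitrogen is thus not sufficient by itself, as 1,1-dioxothian-4-yl in place of cyclohexyl brings an at least 100-fold higher number from compound 1 to compound 4 (2.01 log units; beyond the scatter). The steps to compound 4 from compound 2 and from compound 3 cannot be read, as both ends of each are limits, and sec-butyl, cyclopropyl and 1,1-dioxothian-4-yl cannot be ranked against one another.

Open, from the compounds shown here alone, is whether a ring of another size, such as cyclopentyl or cycloheptyl, keeps a measurable value at this position. Also open, going by these compounds, is whether the sulfur or the two oxygens of 1,1-dioxothian-4-yl go with the loss, a question that thian-4-yl, with the sulfur and without the oxygens, could separate.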